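A few compounds are considered here, and "the series" means these few. Any claim that something is new, unique, unknown or untested is made for them only; others in the source may bear on it.

Among the measured compounds shown here, compound 2, with the structure `COc1cc2cc(Oc3ccc(NC(=O)Nc4ccc(Cl)c(C(F)(F)F)c4)cc3)c(C)nc2cc1OC`, gives the lowest of the two numbers so far in a functional assay on HOP-62 cells (Homo sapiens) for inhibition, read by sulforhodamine B assay, with a stated time of 48 h (a higher number here means a weaker inhibitor of growth, a lower number a stronger inhibitor of growth), where compound 2 shows 5320 nM. The nearest neighbour is compound 1, with the structure `COc1cc2cc(Oc3ccc(NC(=O)Nc4cccc(C(F)(F)F)c4)cc3)c(C)nc2cc1OC`, and in this assay compound 1 shows 8440 nM. For the measured compounds named here, the single measured step, a 1.6-fold lower number from compound 1 to compound 2 (0.20 log units; within the scatter), lies within the scatter of the method.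

The next compound, compound 3, has the structure `COc1cc2cc(Oc3ccc(NC(=O)Nc4ccc(Cl)c(Cl)c4)cc3)c(C)nc2cc1OC`. Its difference from compound 2 is chloro in place of trifluoromethyl on an aromatic carbon. Going by the values given here, only the step from compound 1 to compound 2 bears on this change, and it concerns a different substituent; it stayed within the scatter, so there is no measured case where a change at the terminal phenyl ring moved the number beyond the scatter. The step of a 1.0-fold lower number from compound 2 to compound 3 (0.00 log units; within the scatter) is therefore expected to be small, with no direction that can be trusted. Compound 3 is accordingly estimated to give 5300 nM in this assay, within a range from 2500 nM to 11000 nM.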

Compound 3, concentration for total growth inhibition: 11900 nM
Compound 3: the middle estimate sits 2.2-fold (0.35 log units) below what was measured; measured number above the stated range.
By their numbers in this assay, from the lowest: compounds 2, 1 and 3 (each within the scatter of the next, the first and the last beyond it).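

Among the compounds shown here, at this aromatic carbon, ortho to a chloro group and meta to a large group, chloro in place of trifluoromethyl gives a 2.2-fold higher number from compound 2 to compound 3 (0.35 log units; beyond the scatter) in this assay and is the first step to pass beyond the scatter, although only modestly. Compound 3 is thus a weaker inhibitor of growth than compound 2, so with the chloro group held in place, the two substituents at this carbon are not interchangeable in this modest sense, while the comparison of 3,4-dichlorophenyl with 3-(trifluoromethyl)phenyl gives a 1.4-fold higher number from compound 1 to compound 3 (0.15 log units; within the scatter) and stays within the scatter, so compound 1 cannot be separated from compound 3. Nothing available explains why the trifluoromethyl group fares better here than chloro.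

The compounds shown leave open whether the step would be the same size without the neighbouring chloro group, since the only comparison of these two substituents has that group present. They also leave open how a methoxy group, a nitrile or an amine at this same carbon would compare with trifluoromethyl and chloro.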